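Swapping Fluoro for Hydroxy on the Aryl Ring

The source may report more compounds than this note shows. Statements on the series, on what has been measured and on what is new or still open speak of the compounds shown alone.

Compound 1 `O=C1CSC(c2cccc(F)c2)N1CCN1CCCCC1` is one of three compounds tested in an ADME assay on Vero cells (Chlorocebus sabaeus) for cytotoxicity, read by neutral red uptake, tested at 394 ug/mL; on this read-out lower numbers stand for a stronger effect and higher numbers for a weaker effect at the one concentration tested. In this assay compound 1 gives 60%, the second highest of the three numbers. Compound 3 `COc1ccccc1C1SCC(=O)N1CCN1CCCCC1` gives 67%, a value within the scatter of compound 1, so the two cannot be placed in order. Compound 2 `O=C1CSC(c2ccccc2Cl)N1CCN1CCCCC1` gives 31%, and the step of a number 29 percentage points lower from compound 1 to compound 2 (beyond the scatter) lies beyond the scatter. The largest measured step is a number 36 percentage points higher from compound 2 to compound 3 (beyond the scatter).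

Compound 4 `O=C1CSC(c2cccc(O)c2)N1CCN1CCCCC1` differs from compound 1 by hydroxy in place of fluoro on an aromatic carbon. Going by the values given here, no measured step exchanges exactly these two groups. The closest guide is a number 36 percentage points higher from compound 2 to compound 3 (beyond the scatter), where a halogen also gave way to an oxygen-bearing group on an aromatic carbon. That step, though, started from chloro rather than fluoro, and the step of a number 29 percentage points lower from compound 1 to compound 2 (beyond the scatter) changed both the halogen and its position, so neither transfers directly. For compound 4 the expected step is therefore small or none beyond the scatter, a number 7 percentage points higher from compound 1 to compound 4 (within the scatter). Compound 4 is estimated at 67%, with a range from 50% to 84%.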

Compound 4, a percentage reported as activity, at one concentration (the size of the read-out at that concentration, not a potency): 100%
The estimate for compound 4 lay 33 percentage points below the measured number, outside the stated range (above it).
By their numbers in this assay, from the lowest: compound 2; then compounds 1 and 3 (each within the scatter of the next); then compound 4.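

In this assay, exchanging fluoro for hydroxy on the aromatic ring gives a number 40 percentage points higher from compound 1 to compound 4 (beyond the scatter). This is a higher number and a weaker effect at the one concentration tested, and the two compounds differ by a single atom at this place. Compared with the 2-chlorophenyl group, the 3-hydroxyphenyl group gives a number 69 percentage points higher from compound 2 to compound 4 (beyond the scatter), a wider gap than any step among the earlier compounds. No measurement available here explains why hydroxy has this effect.

This single pair cannot show whether the rise belongs to hydroxy itself or would also appear with another group, such as an amine or a carboxylic acid, at this place on the ring. As far as these compounds go, whether hydroxy would give a similar number at other places on the ring also remains open.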